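This account rests on a few compounds, and the source may have more. Where it says the series, first, only, none or still open, it means among the compounds named here.

Compound 2 `COC(=O)C1=C(C)N=C(C)/C(=C(\O)OC)C1c1ccccc1I` stands at the lowest number of the three compounds measured in a functional assay (muscle tissue) with Cavia porcellus as the target (on this read-out lower numbers stand for an effect already at smaller amounts and higher numbers for an effect only at larger amounts of compound), where compound 2 gives 46.8 nM. Compound 1 `COC(=O)C1=C(C)N=C(C)/C(=C(\O)OC)C1c1ccc(I)cc1` gives 22900 nM and compound 3 `COC(=O)C1=C(C)N=C(C)/C(=C(\O)OC)C1c1cccc(N)c1` gives 2000 nM. Compound 4 `CCOc1ccccc1C1C(C(=O)OC)=C(C)N=C(C)/C1=C(\O)OC` differs from compound 2 by ethoxy in place of iodo on an aromatic carbon. For the measured compounds named here, no measured step swaps one group for another at the same position; the nearest guides are a 490-fold lower number from compound 1 to compound 2 (2.69 log units; beyond the scatter), which shows how much the place of the iodo matters, and a 43-fold higher number from compound 2 to compound 3 (1.63 log units; beyond the scatter). Since compound 4 keeps the position but loses the iodo, a moderate rise in the number is expected, a 3.2-fold higher number from compound 2 to compound 4 (0.51 log units; beyond the scatter). Compound 4 is therefore estimated at 150 nM, within a range from 40 nM to 600 nM.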

Compound 4, half-maximal effective concentration: 110 nM
Estimate against measurement, compound 4: 1.4-fold (0.13 log units) above; low and high end bracket the measured number.
By their numbers in this assay, from the lowest: compound 2; then compound 4; then compound 3; then compound 1.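

Iodo is not the only group that gives a low number at this place: with ethoxy on the aromatic carbon ortho to a large group, this assay shows a 2.4-fold higher number from compound 2 to compound 4 (0.37 log units; beyond the scatter), a modest step. Iodine itself is therefore not required here, and a group of 3 heavy atoms with a hydrogen-bond acceptor keeps the number low. No supporting measurement explains the size of this step.

On these data alone, it remains open how an amine or a longer propoxy chain would fare at this place. As far as these compounds go, whether ethoxy depends on its place as strongly as iodo does also remains open.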